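Trimming the Naphthalen-2-yl Amide of Compound 1

This account rests on a few compounds, and the source may have more. Where it says the series, first, only, none or still open, it means among the compounds named here.

Compound 1, `O=C(CSc1ccc(Cl)cc1)Nc1ccc2nc(NC(=O)c3ccc4ccccc4c3)sc2c1`, carries an amide built from a naphthalen-2-yl group on one side of its shared core. In a functional assay on U2OS cells (Homo sapiens) for antiproliferative activity, read by MTT assay, with a stated time of 72 h (on this read-out lower numbers stand for stronger inhibition and higher numbers for weaker inhibition), compound 1 gives 14500 nM, and this is the only numeric result in the set. Compound 2, `CC(O)c1cccc(NC(=O)c2cc(Br)ccc2Br)c1`, reached only a limit of the assay in this assay, recorded as > 100000 nM. That limit is the point (the limit of > 100000 nM in this assay, at which 1 of the 2 values shown sits), so compound 2 supplies no number against which compound 1 can be ranked.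

Compound 3, `Cc1ccc(C(=O)Nc2nc3ccc(NC(=O)CSc4ccc(Cl)cc4)cc3s2)cc1`, has not yet been measured. It differs from compound 1 in one place: 4-methylphenyl in place of naphthalen-2-yl on a carbonyl carbon. Among the measured compounds shown here, no pair of measured compounds that differ in a single place is available here, so nothing shows how this assay responds to swapping one aromatic amide group for another.

Given only the result of compound 1, 14500 nM, compound 3 is expected to be somewhat weaker, with a step of a 1.5-fold higher number from compound 1 to compound 3 (0.18 log units; within the scatter) that may not exceed the usual scatter. Compound 3 is estimated at 22000 nM, in the range 7000 nM to 70000 nM.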

Compound 3, half-maximal inhibitory concentration: 3190 nM
Compound 3: the middle estimate sits 6.9-fold (0.84 log units) above what was measured; the measured number lies below the stated range.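

Among the compounds shown here, at the carbonyl carbon of the amide, the first comparison in this assay between compounds that differ in one place shows that the activity depends on the aromatic group held there: a 4.5-fold lower number from compound 1 to compound 3 (0.66 log units; beyond the scatter). The change removes naphthalen-2-yl, with its 2 six-membered aromatic rings of carbon only, and brings in 4-methylphenyl, with one such ring, so the larger group is not required for activity in these cells, and the smaller group here gives the lower number. No measured property among the results shown accounts for the size of this step.

From the compounds shown here alone, whether the lower number comes from losing the second ring or from gaining the methyl group stays open, since a single step changes both at once, and an unsubstituted phenyl or a 4-methoxyphenyl group on the same carbonyl carbon would be needed to separate the two. Going by these compounds, it also remains unknown whether this position accepts a saturated ring such as cyclohexyl, or an aromatic group carrying an amine or a carboxylic acid.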